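The source may report more compounds than this note shows. Statements on the series, on what has been measured and on what is new or still open speak of the compounds shown alone.

The measured compounds in an assay on isolated protein for inhibition of alkaline phosphatase, tissue-nonspecific isozyme (Bos taurus), read by spectrophotometry, with stated times of 7 min and 15 min (on this read-out higher numbers stand for weaker inhibition and lower numbers for stronger inhibition), are these:

Compound 1 `CCCCCc1cc(=O)c2cc([N+](=O)[O-])ccc2n1Cc1ccc(OC)cc1` gives 1510 nM in this assay.
Compound 2 `COc1ccc(Cn2c(-c3ccc(C)cc3)c(Br)c(=O)c3cc([N+](=O)[O-])ccc32)cc1` gives 4220 nM in this assay.
Compound 3 `COc1ccc(Cn2c(-c3ccc(C)cc3)c(-c3cc(C)cc(C)c3)c(=O)c3cc([N+](=O)[O-])ccc32)cc1` gives 4740 nM in this assay.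

Compound 3 thus stands with the highest of the three numbers. Its nearest neighbour is compound 2, whose number differs from it by a margin that falls within the scatter, so the two cannot be ordered. Compound 1 gives the lowest number, and that difference from compound 3 lies beyond the scatter.

Compound 4 `COc1ccc(Cn2c(-c3ccc(C)cc3)c(C(F)(F)F)c(=O)c3cc([N+](=O)[O-])ccc32)cc1` differs from compound 3 by a single change: trifluoromethyl in place of 3,5-dimethylphenyl on an aromatic carbon. For the measured compounds named here, only one measured step touches the same carbon, namely a 1.1-fold higher number from compound 2 to compound 3 (0.05 log units; within the scatter). There a small group of one heavy atom and a six-membered aromatic ring gave numbers that could not be told apart, which suggests that this carbon tolerates quite different substituents without a shift in this assay. Since trifluoromethyl is again a small group at that carbon, the step from compound 3 to compound 4 is expected to stay within the scatter, a 1.1-fold lower number from compound 3 to compound 4 (0.05 log units; within the scatter), with no clear direction. Compound 4 is accordingly estimated at 4200 nM, with a range from 1500 nM to 12000 nM.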

Compound 4, half-maximal inhibitory concentration: 4530 nM
Beside the measured number, compound 4's estimate is 1.1-fold (0.03 log units) below it; the range from low to high includes it.
By their numbers in this assay, from the lowest: compound 1; then compounds 2, 4 and 3 (each within the scatter of the next).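

In this assay, the aromatic carbon ortho to a 4-methylphenyl group has now carried three different substituents without any separation in the numbers: the change gives a 1.0-fold lower number from compound 3 to compound 4 (0.02 log units; within the scatter), and the exchange of bromo gives a 1.1-fold higher number from compound 2 to compound 4 (0.03 log units; within the scatter). The earlier pair set only bromo against 3,5-dimethylphenyl, whereas trifluoromethyl adds a third kind of substituent, one with fluorine atoms and no ring, so across compound 2, compound 3 and compound 4 neither the presence of the six-membered aromatic ring nor the choice between bromo and trifluoromethyl shifts the result beyond the scatter. Nothing presented with these results offers an explanation for this flat response.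

As far as these compounds go, the trifluoromethyl and 3,5-dimethylphenyl groups both count no hydrogen-bond donors or acceptors, so it remains open whether an amine or a carboxylic acid on this carbon would also leave the number in place. From the compounds shown here alone, compound 1, at 1510 nM, differs from these three compounds in more than one place, so its value cannot be tied to any single change, and whether this carbon would stay as tolerant without the 4-methylphenyl group also remains open.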